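The source may hold more compounds than are shown below. What is called first, only, known or untested is meant among the compounds shown, and "the series" means these compounds.

Compound 2, `CCN(CC)c1ccc2cc(C(=O)c3ccc(N4CCN(S(=O)(=O)c5ccc([N+](=O)[O-])cc5)CC4)cc3)oc2c1`, gives the lowest of the two plain numbers recorded in a functional assay on A549 cells (Homo sapiens) for cytotoxicity, read by MTT assay, with a stated time of 48 h (on this read-out lower numbers stand for stronger inhibition and higher numbers for weaker inhibition), namely 24400 nM. Its closest neighbour is compound 1, `CCN(CC)c1ccc2cc(C(=O)c3ccc(N4CCN(S(=O)(=O)c5ccc(Br)cc5)CC4)cc3)oc2c1`, which in this assay gives 34300 nM; the step of a 1.4-fold lower number from compound 1 to compound 2 (0.15 log units; within the scatter) is therefore not a real difference. Compound 3, `CCOC(=O)N1CCN(c2ccc(C(=O)c3cc4ccc(N(CC)CC)cc4o3)cc2)CC1`, is reported in this assay only as a limit of > 40000 nM. Because of the limit of > 40000 nM in this assay, at which 1 of the 3 values shown sits, the steps from compound 1 and compound 2 toward compound 3 can only be read as floors, and even those floors, an at least 1.1-fold higher number from compound 1 to compound 3 (0.06 log units; that floor lies within the scatter) and an at least 1.6-fold higher number from compound 2 to compound 3 (0.21 log units; that floor lies within the scatter), stay within the scatter.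

Compound 4, `CCN(CC)c1ccc2cc(C(=O)c3ccc(N4CCN(S(=O)(=O)c5ccc(C(F)(F)F)cc5)CC4)cc3)oc2c1`, differs from compound 2 in one place: trifluoromethyl in place of nitro on an aromatic carbon. Among the compounds with values here, the only measured step that touches this same aromatic carbon is the exchange of bromo for nitro between compound 1 and compound 2, and that step stayed within the scatter. Within the data shown here, no measured step shows what a trifluoromethyl group does here. On that basis the step of a 1.1-fold higher number from compound 2 to compound 4 (0.06 log units; within the scatter) is expected to bring no shift beyond the scatter. Compound 4 is therefore estimated to give about 28000 nM in this assay, with a plausible range from 12000 nM to 65000 nM, and a real chance that only a limit is reported.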

Compound 4, half-maximal inhibitory concentration: 11100 nM
Compound 4: middle estimate off by 2.5-fold (0.40 log units), on the high side, outside the stated range (below it).
By their numbers in this assay, from the lowest: compound 4; then compounds 2 and 1 (each within the scatter of the next). At a limit, above all of these: compound 3.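

Up to this point, the group on this aromatic carbon, para to a large group, had shown no effect that could be told from the scatter, since bromo and nitro could not be separated. In this assay, within the data shown here, the 4-(trifluoromethyl)phenyl group gives the first steps at this position that clear the scatter: a 2.2-fold lower number from compound 2 to compound 4 (0.34 log units; beyond the scatter) and a 3.1-fold lower number from compound 1 to compound 4 (0.49 log units; beyond the scatter). Both steps are modest, but they show that the number can move with the group placed on this carbon, and that the exchange of nitro for trifluoromethyl is not silent here, even though the exchange of bromo for nitro gave no readable change.

On these data alone, what a nitrile, a methoxy group, an amine or a plain hydrogen would give on this same aromatic carbon remains open, so three groups cannot yet be read as a trend. How far compound 4 stands from the ethoxycarbonyl compound, compound 3, also stays open, and no size can be given to that gap: the limit of > 40000 nM in this assay, at which 1 of the 4 values shown sits.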